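A few compounds are considered here, and "the series" means these few. Any claim that something is new, unique, unknown or untested is made for them only; others in the source may bear on it.

In an ADME assay on S2 cells (Drosophila melanogaster) for cytotoxicity, read by MTT assay (on this read-out higher numbers stand for an effect only at larger amounts of compound and lower numbers for an effect already at smaller amounts), three compounds of the same core have been examined so far. Compound 1, `O=C(/C=C/[C@H]1C[C@@H](O)[C@@H](O)C1)Oc1ccccc1`, gives only a limit of this assay, > 200000 nM. Compound 2, `CN(C)C(=O)/C=C/[C@H]1C[C@@H](O)[C@@H](O)C1`, also gives only a limit, > 250000 nM. Compound 3, `O=C(/C=C/[C@H]1C[C@@H](O)[C@@H](O)C1)Nc1ccc(C(F)(F)F)cc1`, likewise gives only a limit, > 160000 nM. Compound 3 thus stands at the limit of > 160000 nM in this assay, at which 1 of the 3 values shown sits, and not at a number. Compound 1 stands at the limit of > 200000 nM in this assay, at which 1 of the 3 values shown sits. Compound 2 stands at the limit of > 250000 nM in this assay, at which 1 of the 3 values shown sits. Compound 4, `CN(C)c1ccc(NC(=O)/C=C/[C@H]2C[C@@H](O)[C@@H](O)C2)cc1`, differs from compound 3 by dimethylamino in place of trifluoromethyl on an aromatic carbon. Within the data shown here, none of the measured compounds gives a number, so no step size can be drawn from them; compound 4 is expected to show a step that the limit leaves unreadable from compound 3 to compound 4, nothing beyond the scatter. Compound 4 is estimated at 200000 nM in this assay, between 100000 nM and 400000 nM, and is expected to be reported as a limit again.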

Compound 4, half-maximal effective concentration: > 170000 nM
Compound 4 gave a limit, no number; the forecaster's own chance of this, stated with the estimate: 80%; the middle value does not contradict the limit.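

Compound 3 and compound 4 both give only limits in this assay, so no step can be read between them. The compounds shown leave open at what concentration any of them would show an effect.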